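The source may report more compounds than this note shows. Statements on the series, on what has been measured and on what is new or still open speak of the compounds shown alone.

Compound 1, `FC(F)(F)c1cccc(/N=N/N2CCCC2)c1`: > 100000 nM
Compound 2, `FC(F)(F)c1cccc(N(C[C@@H]2CCCN3CCCC[C@H]23)/N=N/c2ccccc2)c1`: 22000 nM
Compound 3, `CN1CCN(/N=N/c2cc(F)ccc2F)CC1`: > 100000 nM

All three compounds were tested in an ADME assay on MDBK cells (Bos taurus) for cytotoxicity, read by MTT assay, with a stated time of 96 h; on this read-out lower numbers stand for higher toxicity in this test and higher numbers for lower toxicity in this test. For compound 1 the result in this assay is a limit of the test and not a number, > 100000 nM. Compound 3 likewise gives only a limit in this assay, > 100000 nM. Compound 2 alone gives a number, 22000 nM. Compound 1 therefore stands at the limit of > 100000 nM in this assay, at which 2 of the 3 values shown sit, together with compound 3, while compound 2 lies apart from them.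

Compound 4, `Clc1cccc(/N=N/N2CCCC2)c1`, has not yet been measured. It differs from compound 1 in one place: chloro in place of trifluoromethyl on an aromatic carbon. Within the data shown here, no pair of measured compounds shows this change, so there is no measured step to lean on. The expected step from compound 1 to compound 4 in this assay is a number no higher from compound 1 to compound 4 (the limit leaves the size open), that is, none beyond the scatter. Compound 4 is accordingly expected to give 100000 nM in this assay, within 30000 nM to 300000 nM, and most likely the result will again be reported only as a limit.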

Compound 4, half-maximal cytotoxic concentration: > 100000 nM
Compound 4 was reported as a limit; the forecaster's own chance of this, stated with the estimate: 70%; the middle value sits exactly at the limit.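

Compound 1 and compound 4 both give only a limit in this assay, so the step between them cannot be read: the limit of > 100000 nM in this assay, at which 3 of the 4 values shown sit.

The compounds shown leave open whether chloro in place of trifluoromethyl on an aromatic carbon changes the result in this assay at all.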